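Methyl for fluoro on the carbonyl aryl ring: cytotoxicity outlook

The compounds below may be only part of what the source reports. "The series", "measured", "known", "first", "only" and "open" are said of these compounds alone.

Of the compounds shown here, three sharing one core have been tested in an ADME assay on L929 cells (Mus musculus) for cytotoxicity, read by resazurin assay, with a stated time of 72 h; a higher number here means a weaker inhibitor, a lower number a stronger inhibitor. Compound 1 `OB1OCc2ccc(-n3ccc4ccccc43)cc21` gives > 10 ug/mL in this assay, which is a limit of the assay rather than a number. Compound 2 `O=C(c1ccn(-c2ccc3c(c2)B(O)OC3)c1)c1ccccc1Cl` likewise gives > 10 ug/mL, again only a limit. Compound 3 `O=C(c1ccc(F)cc1)c1ccn(-c2ccc3c(c2)B(O)OC3)c1` gives > 10 ug/mL, a limit as well. Compound 3 therefore stands exactly where every measured compound stands, because all three sit at the limit of > 10 ug/mL in this assay, at which 3 of the 3 values shown sit. Among the measured compounds shown here, the only step that can be traced between two measured compounds, a step that the two limits leave unreadable from compound 2 to compound 3, involves 4-fluorophenyl in place of 2-chlorophenyl on a carbonyl carbon, and its size is not readable.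

Compound 4 `Cc1ccc(C(=O)c2ccn(-c3ccc4c(c3)B(O)OC4)c2)cc1` differs from compound 3 by methyl in place of fluoro on an aromatic carbon. For the measured compounds named here, the one measured step that bears on this change is unreadable, so no size can be carried over from it; what the numbers do show is that three different groups on the carbonyl carbon all gave values at the limit. A step of no readable size is accordingly expected, a step that the limit leaves unreadable from compound 3 to compound 4. Compound 4 is estimated to give 30 ug/mL in this assay, within a range from 10 ug/mL to 100 ug/mL, and most probably reported once more only as a limit.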

Compound 4, half-maximal inhibitory concentration: > 10 ug/mL
Compound 4: a limit, no number (the forecaster's own chance of this, stated with the estimate: 85%); the middle value does not contradict the limit.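

In this assay compound 4 gives > 10 ug/mL, which is a limit and not a number. Its steps from compound 2 and from compound 3 therefore cannot be read. The compounds shown leave open how strongly any of them acts in this assay, and whether any group on the carbonyl carbon changes that at all: the limit of > 10 ug/mL in this assay, at which 4 of the 4 values shown sit.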